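Swapping the nitrophenyl amine of compound 1 for a hydroxyphenyl

This account rests on a few compounds, and the source may have more. Where it says the series, first, only, none or still open, it means among the compounds named here.

Compound 1 `CC(C)c1ccc(-c2nc(SCc3cn(CC(=O)NC(=O)Nc4ccccn4)nn3)nc(Nc3cccc([N+](=O)[O-])c3)c2C#N)cc1` sits at the limit of a functional assay on MGC-803 cells (Homo sapiens) for inhibition, read by MTT assay, with a stated time of 72 h; a higher number here means a weaker inhibitor, a lower number a stronger inhibitor: compound 1 gives only > 64000 nM, a limit rather than a number, at the limit of > 64000 nM in this assay, at which 1 of the 2 values shown sits. Compound 2 `Cc1ccccc1Nc1nc(SCc2cn(CC(=O)NC(=O)Nc3ccccn3)nn2)nc(-c2ccc(C(C)C)cc2)c1C#N` gives 19000 nM in this assay, so there is an at least 3.3-fold lower number from compound 1 to compound 2 (0.52 log units; beyond the scatter). Compound 3 `CC(C)c1ccc(-c2nc(SCc3cn(CC(=O)NC(=O)Nc4ccccn4)nn3)nc(Nc3ccccc3O)c2C#N)cc1` differs from compound 1 by 2-hydroxyphenyl in place of 3-nitrophenyl on a nitrogen on an aromatic ring. Among the compounds with values here, the only measured step that bears on this is the one from compound 1 to compound 2, which also removed the 3-nitrophenyl and was at least modest; a step of similar direction in this assay is therefore expected, an at least 2.1-fold lower number from compound 1 to compound 3 (0.32 log units; beyond the scatter). Compound 3 is estimated at 30000 nM, between 10000 nM and 90000 nM.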

Compound 3, half-maximal inhibitory concentration: 16400 nM
Compound 3: middle estimate off by 1.8-fold (0.26 log units), on the high side; low and high end bracket the measured number.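

In this assay, a second replacement of the 3-nitrophenyl on this nitrogen gives an at least 3.9-fold lower number from compound 1 to compound 3 (0.59 log units; beyond the scatter). Compound 1 holds a limit and not a number: the limit of > 64000 nM in this assay, at which 1 of the 3 values shown sits.

The 2-methylphenyl and the 2-hydroxyphenyl on this nitrogen are not separated, with a 1.2-fold lower number from compound 2 to compound 3 (0.06 log units; within the scatter), so methyl and hydroxy on that aromatic carbon read alike here.

On these data alone, it stays open whether the step follows from losing the 3-nitrophenyl or from what enters in its place. As far as these compounds go, it also stays open whether an amine in place of the hydroxy would read the same in this assay.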